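Tosyl capping of the phenol in the triazole series

The source may report more compounds than this note shows. Statements on the series, on what has been measured and on what is new or still open speak of the compounds shown alone.

Measured compounds:
compound 1 `C=C1C(=O)[C@]23C[C@@]1(O)CC[C@H]2c1ccc(OS(=O)(=O)c2ccc(C)cc2)c(C)c1[C@@H]3Cn1cc(-c2ccc(C)cc2)nn1`: 4410 nM
compound 2 `C=C1C(=O)[C@]23C[C@@]1(O)CC[C@H]2c1ccc(O)c(C)c1[C@@H]3Cn1cc(-c2ccc(OC)cc2)nn1`: 860 nM

In a functional assay on SMMC-7721 cells (Homo sapiens) for cytotoxicity, read by MTT assay, with a stated time of 4 days (on this read-out lower numbers stand for stronger inhibition and higher numbers for weaker inhibition), compound 2 gives the lowest of the two numbers; compound 1 sits at a higher number, beyond the scatter. Compound 3 `C=C1C(=O)[C@]23C[C@@]1(O)CC[C@H]2c1ccc(OS(=O)(=O)c2ccc(C)cc2)c(C)c1[C@@H]3Cn1cc(-c2ccc(OC)cc2)nn1` is not yet measured. It differs from compound 2 by (4-methylphenyl)sulfonyl in place of hydrogen on an oxygen on an aromatic ring. For the measured compounds named here, no single-point step between measured compounds is available to size this change. Going by the values given here, the only compound carrying the same sulfonyl group, compound 1, also differs in the triazole substituent, so its higher value is not a clean guide. A moderate rise is expected, step a 2.3-fold higher number from compound 2 to compound 3 (0.37 log units; beyond the scatter). Compound 3 is estimated at 2000 nM, range 700 nM to 6000 nM.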

Compound 3, half-maximal inhibitory concentration: 1720 nM
Compound 3: the middle estimate sits 1.2-fold (0.07 log units) above what was measured, within the range that was stated.
By their numbers in this assay, from the lowest: compounds 2 and 3 (each within the scatter of the next); then compound 1.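

In this assay, placing (4-methylphenyl)sulfonyl on the oxygen gives a 2.0-fold higher number from compound 2 to compound 3 (0.30 log units; within the scatter), so with the methoxy-bearing triazole substituent, this cap on the aromatic oxygen is tolerated within the scatter. For the compounds shown here, with that cap held constant, methoxy in place of methyl on an aromatic carbon gives a 2.6-fold lower number from compound 1 to compound 3 (0.41 log units; beyond the scatter), the only step here that lies beyond the scatter, though modest. Nothing at hand explains either step.

Still open, going by these compounds, is how other groups on this oxygen, such as acetyl or a longer alkyl chain, compare with the hydroxy of compound 2. Also open, on these data alone, is whether the methoxy and methyl difference persists when the hydroxy is free.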